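The compounds below may be only part of what the source reports. "The series", "measured", "known", "first", "only" and "open" are said of these compounds alone.

In a functional assay on KB cells (Homo sapiens) for antiproliferative activity (a higher number here means a weaker inhibitor, a lower number a stronger inhibitor), compound 1 `COc1ccc(S(=O)(=O)N2CCc3cccc(Nc4ccc(Cl)cc4)c32)cc1` gives 1100 nM, compound 2 `COc1ccc(S(=O)(=O)N2CCc3cccc(Nc4ccc(F)cc4)c32)cc1` gives 557 nM and compound 3 `COc1ccc(S(=O)(=O)N2CCc3cccc(Nc4ccc([N+](=O)[O-])cc4)c32)cc1` gives 101 nM. Compound 2 holds the middle number of the three, but the data show a 2.0-fold lower number from compound 1 to compound 2 (0.30 log units; within the scatter), so it stays level with its chloro partner. The data also show a 5.5-fold lower number from compound 2 to compound 3 (0.74 log units; beyond the scatter). Compound 4 `COc1ccc(S(=O)(=O)N2CCc3cccc(Nc4ccc(C#N)cc4)c32)cc1` departs from compound 2 by cyano in place of fluoro on an aromatic carbon. Among the compounds with values here, no cyano step has been measured, so the nearest guides are that nitro step and an 11-fold lower number from compound 1 to compound 3 (1.04 log units; beyond the scatter). A modest step to a lower number in this assay is therefore expected, probably smaller than the nitro step. The expected change is a 2.8-fold lower number from compound 2 to compound 4 (0.44 log units; beyond the scatter). Compound 4 is estimated at 200 nM, with an expected range of 70 nM to 550 nM.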

Compound 4, half-maximal inhibitory concentration: 49.7 nM
Compound 4: middle estimate off by 4.0-fold (0.60 log units), on the high side; measured number below the stated range.
By their numbers in this assay, from the lowest: compound 4; then compound 3; then compounds 2 and 1 (each within the scatter of the next).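

In this assay, cyano in place of nitro gives a 2.0-fold lower number from compound 3 to compound 4 (0.31 log units; beyond the scatter), so the nitro group no longer marks the low end of the numbers at this position, para to a large group. Cyano in place of fluoro gives an 11-fold lower number from compound 2 to compound 4 (1.05 log units; beyond the scatter), and cyano in place of chloro gives a 22-fold lower number from compound 1 to compound 4 (1.35 log units; beyond the scatter), which widens the span this single position can cover. The change adds only one heavy atom to the fluoro compound, yet it moves the number this far.

Nothing available explains the order of these groups. As far as these compounds go, whether an acetyl group, a carboxylic acid or an amine at this position would reach the number of compound 4 stays open.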